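A few compounds are considered here, and "the series" means these few. Any claim that something is new, unique, unknown or untested is made for them only; others in the source may bear on it.

Measured in a functional assay on A549 cells (Homo sapiens) for inhibition, read by sulforhodamine B assay, with a stated time of 72 h (a lower number here means a stronger inhibitor, a higher number a weaker inhibitor), so far:

- Compound 1 `COc1cc2c(Nc3ccc(F)c(Cl)c3)ncnc2cc1OCCOCCn1ccnc1[N+](=O)[O-]` at 7640 nM
- Compound 2 `COc1cc2c(Nc3ccc(OCc4cccc(F)c4)c(Cl)c3)ncnc2cc1OCCCCCn1ccnc1[N+](=O)[O-]` at 14400 nM

In this assay compound 2 lies within the usual scatter of compound 1 and the pair sets no order between them. Both sit in the same broad range.

Compound 3 `COc1cc2c(Nc3ccc(OCc4cccc(F)c4)c(Cl)c3)ncnc2cc1OCCOCCn1ccnc1[N+](=O)[O-]` has not yet been measured. It differs from compound 2 in one place: 2-(2-nitro-1H-imidazol-1-yl)ethoxy in place of 3-(2-nitro-1H-imidazol-1-yl)propyl on a saturated chain carbon, two bonds along the chain from an oxygen on an aromatic ring and the change falls on a saturated chain carbon, two bonds along the chain from an oxygen on an aromatic ring.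

For the measured compounds named here, no two measured compounds differ in one place alone, so no measured step speaks directly for this change. Going by the values given here, the only guide is how close the two values are, with compound 1 at 7640 nM and compound 2 at 14400 nM in the same range. On that basis no step beyond the scatter is expected, with at most a slight lean toward a lower number. The expected move is a 1.4-fold lower number from compound 2 to compound 3 (0.16 log units; within the scatter) and it stays small. Compound 3 is expected at 10000 nM in this estimate, with an estimated range from 4000 nM to 25000 nM as the likely span.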

Compound 3, half-maximal inhibitory concentration: 6230 nM
Compound 3: middle estimate off by 1.6-fold (0.21 log units), on the high side; measured number inside the range.
By their numbers in this assay, from the lowest: compounds 3, 1 and 2 (each within the scatter of the next, the first and the last beyond it).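

Across the change from 3-(2-nitro-1H-imidazol-1-yl)propyl to 2-(2-nitro-1H-imidazol-1-yl)ethoxy, on a saturated chain carbon, two bonds along the chain from an oxygen on an aromatic ring, this assay records a 2.3-fold lower number from compound 2 to compound 3 (0.36 log units; beyond the scatter) and so gives the first single-place step in the series that clears the scatter, though only modestly. Both groups have 11 heavy atoms, and the entering group has one oxygen more and one carbon fewer, so this pair ties the step to that swap without a change in the printed heavy-atom total. With the oxygen-containing chain held constant, (3-fluorobenzyl)oxy in place of fluoro on an aromatic carbon gives a 1.2-fold lower number from compound 1 to compound 3 (0.09 log units; within the scatter) and stays within the scatter, so this pair sets no order between compound 1 and compound 3, and nothing measured here accounts for either step.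

The compounds shown leave open whether an amine in place of the chain oxygen, or a longer chain carrying it, would move the number further. Going by these compounds, all of them also carry the 2-nitroimidazole end, so what a plain imidazole or a morpholine at the end of the chain would do remains unknown.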